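The source may hold more compounds than are shown below. What is called first, only, known or untested is meant among the compounds shown, and "the series" means these compounds.

Of the compounds shown here, two have been measured so far in a functional assay on ECa-109 cells (Homo sapiens) for antiproliferative activity, read by MTT assay, with a stated time of 48 h; a lower number here means a stronger inhibitor, a higher number a weaker inhibitor. Compound 1 `Cn1cc(C2=C(c3nn(CCCCn4ccnc4)c4ncccc34)C(=O)N(c3ccccc3)C2=O)c2ccccc21` carries a phenyl group on the amide-type nitrogen of its five-membered ring, and in this assay compound 1 gives 7540 nM. Compound 2 `Cn1cc(C2=C(c3nn(CCCN4CCCCC4)c4ncccc34)C(=O)NC2=O)c2ccccc21` has a hydrogen on that nitrogen instead and also carries a different side chain on the other side of the shared core; in this assay compound 2 gives 42300 nM. Compound 2 therefore stands at the higher of the two numbers, and its gap to compound 1 lies well beyond the usual scatter. Two features differ at once between compound 1 and compound 2, so the gap cannot be assigned to either feature alone.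

Compound 3 `Cn1cc(C2=C(c3nn(CCCN4CCCCC4)c4ncccc34)C(=O)N(c3ccccc3)C2=O)c2ccccc21` keeps the side chain of compound 2 and makes one single change: phenyl in place of hydrogen on an amide-type nitrogen in a ring. Going by the values given here, no measured pair isolates this change, so any expectation rests on compound 1 alone, whose value 7540 nM is the only one with a phenyl group in place. A moderate move toward a lower number, beyond the scatter, is expected, amounting to a 3.5-fold lower number from compound 2 to compound 3 (0.55 log units; beyond the scatter). Compound 3 is thus estimated at 12000 nM, within a range from 4000 nM to 40000 nM.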

Compound 3, half-maximal inhibitory concentration: 12300 nM
Compound 3: middle estimate off by 1.0-fold (0.01 log units), on the low side; measured number inside the range.
By their numbers in this assay, from the lowest: compounds 1 and 3 (each within the scatter of the next); then compound 2.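

Compound 3 separates the two features that differed at once between compound 1 and compound 2: with the side chain held fixed in this assay, phenyl in place of hydrogen on the amide-type nitrogen in the ring gives a 3.4-fold lower number from compound 2 to compound 3 (0.54 log units; beyond the scatter), so this position responds to the change on its own. With the phenyl group in place, piperidin-1-yl in place of (1H-imidazol-1-yl)methyl on the saturated chain gives a 1.6-fold higher number from compound 1 to compound 3 (0.21 log units; within the scatter), so these two side chains cannot be told apart by these numbers, and the gap between compound 1 and compound 2 is no longer an open question between two features in the same way. Nothing measured here bears on the reason for the step at this nitrogen.

Going by these compounds, it remains open whether a smaller group such as methyl, or a larger one such as benzyl, on that nitrogen would give a similar number, and whether chlorine or methoxy on the phenyl ring would shift it. Also open, on these data alone, is whether the phenyl step keeps its size with the side chain of compound 1.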